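Extending the side chain of compound 2

This account rests on a few compounds, and the source may have more. Where it says the series, first, only, none or still open, it means among the compounds named here.

In a functional assay on MDA-MB-453 cells (Homo sapiens) for cytotoxicity, read by MTT assay, with a stated time of 72 h (on this read-out higher numbers stand for weaker inhibition and lower numbers for stronger inhibition), compound 1 `CC(C)(C)C1=CC(=O)C=C(NCC(=O)O)C1=O` gives 171000 nM and compound 2 `C[C@H](NC1=CC(=O)C=C(C(C)(C)C)C1=O)C(=O)O` gives 112000 nM. These two values lie within the scatter of each other, so compound 2 stands level with compound 1 on the numbers available.

Compound 3 `CSCC[C@H](NC1=CC(=O)C=C(C(C)(C)C)C1=O)C(=O)O` differs from compound 2 by one change: (methylsulfanyl)methyl in place of hydrogen on a saturated chain carbon, two bonds along the chain from an amine nitrogen and a carbonyl carbon. The same difference, cut one bond further out, reads methyl to 2-(methylsulfanyl)ethyl.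

Within the data shown here, only one measured step bears on this change: a 1.5-fold lower number from compound 1 to compound 2 (0.18 log units; within the scatter). That step is methyl in place of hydrogen on a saturated chain carbon bound to an amine nitrogen and a carbonyl carbon, the same chain carbon that changes here. Among the measured compounds shown here, no measured compound carries a sulfur-containing group, so the extrapolation rests on this single small step. With compound 1 and compound 2 this close, no step beyond the scatter is expected, and no direction is firmly supported. The expected step is a 1.2-fold lower number from compound 2 to compound 3 (0.07 log units; within the scatter). For compound 3 the estimate is 95000 nM, with an expected range of 45000 nM to 190000 nM.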

Compound 3, half-maximal inhibitory concentration: 151000 nM
Compound 3: middle estimate off by 1.6-fold (0.20 log units), on the low side; low and high end bracket the measured number.
By their numbers in this assay, from the lowest: compounds 2, 3 and 1 (each within the scatter of the next).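

This series now reaches a chain well beyond methyl at the same carbon. In this assay, adding (methylsulfanyl)methyl on the saturated chain carbon, two bonds along the chain from an amine nitrogen and a carbonyl carbon, gives a 1.3-fold higher number from compound 2 to compound 3 (0.13 log units; within the scatter), and the full 2-(methylsulfanyl)ethyl group in place of hydrogen gives a 1.1-fold lower number from compound 1 to compound 3 (0.05 log units; within the scatter). Both steps lie within the scatter, so hydrogen, methyl and 2-(methylsulfanyl)ethyl at this carbon stand level across compound 1, compound 2 and compound 3, and a group of 3 further heavy atoms, one of them sulfur, separates none of them on these numbers. No supporting data bear on why these values stand level.

Still open, going by these compounds, is whether a different kind of group on this chain carbon, such as an amine-bearing chain, a phenyl ring or a second carboxylic acid, would give a step beyond the scatter. Also open, on these data alone, is whether replacing the carboxylic acid of the side chain with an amide would shift the number.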